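The source may hold more compounds than are shown below. What is called first, only, known or untested is meant among the compounds shown, and "the series" means these compounds.

- compound 1 `CC(=O)c1ncc([C@@H](O)[C@H](O)[C@H](O)CO)s1` gives 65%
- compound 2 `CN(C)C(=O)c1nc([C@@H](O)[C@H](O)[C@H](O)CO)c[nH]1` gives 5%
- compound 3 `OC[C@@H](O)[C@@H](O)[C@H](O)c1c[nH]c(C(F)(F)C(F)(F)F)n1` gives 31%

In an in vivo ADME assay on the whole organism (strain 129/SvEvBrd x C57BL/6) for pharmacokinetics, with Mus musculus as the target (a lower number here means that a smaller share of the oral dose reaches the circulation, a higher number that a larger share of the oral dose reaches the circulation), compound 2 stands lowest of the three at 5% and lies beyond the scatter from both others, with compound 3 nearest and compound 1 furthest. Compound 4 `Cn1cnc(-c2nc([C@@H](O)[C@H](O)[C@H](O)CO)c[nH]2)c1` is still unmeasured and differs from compound 2 as follows: 1-methyl-1H-imidazol-4-yl in place of dimethylcarbamoyl on an aromatic carbon. Within the data shown here, no measured pair differs in one place only, so the step has no direct precedent. Compound 3 shares the core of compound 2 and carries another group in that place. Among the measured compounds shown here, as the only guide, compound 3 gives 31%. A modest upward step in this assay is expected, possibly within the scatter (estimated a number 10 percentage points higher from compound 2 to compound 4 (within the scatter)). For compound 4 the estimated value is 15% (expected range 3% to 40%).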

Compound 4, oral bioavailability: 3%
Compound 4: middle estimate off by 12 percentage points, on the high side; low and high end bracket the measured number.
By their numbers in this assay, from the lowest: compounds 4 and 2 (each within the scatter of the next); then compound 3; then compound 1.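

In this assay, the step of a number 2 percentage points lower from compound 2 to compound 4 (within the scatter) comes with 1-methyl-1H-imidazol-4-yl in place of dimethylcarbamoyl on an aromatic carbon. This gives the series its first one-place comparison: at this position, between two ring nitrogen atoms, an aromatic ring and an open amide group are not told apart by oral bioavailability. Nothing measured on hand speaks to the reason for this. Open, as far as these compounds go, is how an amine, a carboxylic acid or a longer alkyl chain in this place would read in this assay.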